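This account rests on a few compounds, and the source may have more. Where it says the series, first, only, none or still open, it means among the compounds named here.

Compound 1 `CC(C)C[C@H](N)c1cc(C(F)(F)F)ccc1N1CCN(C(=O)COc2ccc(O)cc2)CC1` stands highest of the three numbers in an assay on HEK293 cells for displacement of a labelled ligand from Melanocortin receptor 4 (Homo sapiens) (on this read-out lower numbers stand for stronger inhibition and higher numbers for weaker inhibition), where compound 1 gives 4600 nM. Its nearest neighbour is compound 2 `CC(C)C[C@H](N)c1cc(C(F)(F)F)ccc1N1CCN(C(=O)CSc2ccc(Cl)cc2Cl)CC1`, which in this assay gives 1500 nM, and the furthest is compound 3 `CC(C)C[C@H](N)c1cc(C(F)(F)F)ccc1N1CCN(C(=O)CCC(=O)c2ccc(Cl)cc2)CC1`, which in this assay gives 820 nM. Compound 4 `CCOc1cccc(CC(C)C(=O)N2CCN(c3ccc(C(F)(F)F)cc3[C@@H](N)CC(C)C)CC2)c1` differs from compound 1 in one place: 1-(3-ethoxybenzyl)ethyl in place of (4-hydroxyphenoxy)methyl on a carbonyl carbon. Among the measured compounds shown here, two measured steps bear on this change, since both also replace the 4-hydroxyphenoxy part of compound 1 on the chain carbon bound to the carbonyl carbon. A modest downward step is expected for compound 4 because a 3.1-fold lower number from compound 1 to compound 2 (0.49 log units; beyond the scatter) and because a 5.6-fold lower number from compound 1 to compound 3 (0.75 log units; beyond the scatter). Between those two replacements, a 1.8-fold lower number from compound 2 to compound 3 (0.26 log units; within the scatter), so the size of the gain does not depend much on which group enters. In this assay compound 4 is therefore estimated at 1200 nM, with a range from 400 nM to 4000 nM. This estimate means an expected step of a 3.8-fold lower number from compound 1 to compound 4 (0.58 log units; beyond the scatter).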

Compound 4, inhibition constant: 2200 nM
Estimate against measurement, compound 4: 1.8-fold (0.26 log units) below; the range from low to high includes it.
By their numbers in this assay, from the lowest: compounds 3, 2 and 4 (each within the scatter of the next, the first and the last beyond it); then compound 1.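

In this assay, a 2.1-fold lower number from compound 1 to compound 4 (0.32 log units; beyond the scatter) shows that a third replacement on this carbonyl carbon also gives a lower number than compound 1, and that this does not need chlorine, which 1-(3-ethoxybenzyl)ethyl does not carry. The entering group does make a difference, however: a 2.7-fold higher number from compound 3 to compound 4 (0.43 log units; beyond the scatter), whereas a 1.5-fold higher number from compound 2 to compound 4 (0.17 log units; within the scatter), so the earlier impression that the gain hardly depends on the group no longer holds for all the replacements. No evidence available here bears on this result.

The compounds shown leave open whether an amine, a carboxylic acid or a longer chain on this carbonyl carbon would take the number lower or higher. They also do not tell how a plain benzyl group would compare with the 3-ethoxybenzyl group of compound 4.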